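The compounds below may be only part of what the source reports. "The series", "measured", "known", "first", "only" and "open" are said of these compounds alone.

In a functional assay on SK-N-AS cells (Homo sapiens) for antiproliferative activity, with a stated time of 72 h (a lower number here means a stronger inhibitor, a higher number a weaker inhibitor), three compounds with a shared core have been measured. Compound 1 `Cc1cc(C)cc(C(=O)N(CCC(=O)NCc2ccccc2)Cc2ccc(C(=O)NO)cc2)c1` gives 1860 nM, compound 2 `O=C(CCN(Cc1ccc(C(=O)NO)cc1)C(=O)c1ccccc1)NCc1ccccc1` gives 3310 nM, and compound 3 `CN(C)c1ccc(C(=O)N(CCC(=O)NCc2ccccc2)Cc2ccc(C(=O)NO)cc2)cc1` gives 1420 nM. Two steps fix the standing of compound 3: the data show a 1.3-fold lower number from compound 1 to compound 3 (0.12 log units; within the scatter), and also a 2.3-fold lower number from compound 2 to compound 3 (0.37 log units; beyond the scatter). It therefore sits level with compound 1 and apart from compound 2.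

The next compound is compound 4 `Cc1ccc(C(=O)N(CCC(=O)NCc2ccccc2)Cc2ccc(C(=O)NO)cc2)cc1`, which carries methyl in place of dimethylamino on an aromatic carbon. For the measured compounds named here, no measured step makes this exact swap. The closest evidence is the modest step from hydrogen to dimethylamino already shown, together with a 1.8-fold higher number from compound 1 to compound 2 (0.25 log units; within the scatter), which relates the 3,5-dimethylphenyl compound to the plain phenyl one and stays within the scatter. Methyl-bearing compound 1 and unsubstituted compound 2 thus suggest a value between theirs. The expected change is small and towards a higher number, a 1.5-fold higher number from compound 3 to compound 4 (0.19 log units; within the scatter), near the edge of the scatter. For compound 4 the estimated value is 2200 nM, with an expected range from 1200 nM to 4000 nM.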

Compound 4, half-maximal inhibitory concentration: 910 nM
For compound 4 the middle estimate is 2.4-fold (0.38 log units) above the measured one, outside the stated range (below it).
By their numbers in this assay, from the lowest: compounds 4, 3, 1 and 2 (each within the scatter of the next, the first and the last beyond it).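

In this assay, the 4-methylphenyl group separates from the plain phenyl group (a 3.6-fold lower number from compound 2 to compound 4 (0.56 log units; beyond the scatter)), while methyl and dimethylamino at this place cannot be told apart (a 1.6-fold lower number from compound 3 to compound 4 (0.19 log units; within the scatter)), so among these compounds a nitrogen-bearing group is not needed for that separation. The arrangement of methyl groups also counts: the single methyl para to a large group differs from the 3,5-dimethylphenyl compound (a 2.0-fold lower number from compound 1 to compound 4 (0.31 log units; beyond the scatter)), although that compound stays within the scatter of the plain phenyl one. Nothing measured here accounts for these differences.

As far as these compounds go, whether an ethyl, a methoxy or a carboxylic acid on this same carbon would read like methyl remains open. So does whether the gain from the 4-methylphenyl group would persist if another part of the shared core changed.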